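This account rests on a few compounds, and the source may have more. Where it says the series, first, only, none or still open, it means among the compounds named here.

Working notes on the series in an assay on CV-1 cells (Cercopithecidae) for activation of retinoic acid receptor alpha (Homo sapiens); a lower number here means that less compound is needed, a higher number that more compound is needed for the effect. Compound 1 `Cc1ccc(-c2ccc(C(=O)O)cc2)cc1-c1ccc2c(c1)C(C)(C)CCC2(C)C` gives 79 nM. Compound 2 `Cc1ccc(-c2ccc(C(=O)O)cc2)cc1-c1cc2c(cc1C)C(C)(C)CCC2(C)C` differs from it by a methyl in place of hydrogen on an aromatic carbon of the shared core. In this assay compound 2 reaches only a limit, > 1000 nM. The step is large: an at least 12-fold higher number from compound 1 to compound 2 (1.10 log units; beyond the scatter), with the second value sitting at the limit of > 1000 nM in this assay, at which 1 of the 3 values shown sits. Compound 3 `CC1(C)CCC(C)(C)c2cc(-c3cccc(-c4ccc(C(=O)O)cc4)n3)ccc21` gives 370 nM in this assay, the higher of the two numbers recorded, the gap to compound 1 lying beyond the scatter. The remaining value recorded, that of compound 2, is a limit of the assay and not a number.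

Compound 4 `Cc1cc2c(cc1-c1cccc(-c3ccc(C(=O)O)cc3)n1)C(C)(C)CCC2(C)C` has not been measured. Against compound 3 the change is methyl in place of hydrogen on an aromatic carbon. For the measured compounds named here, one measured step bears on it, the same swap of methyl for hydrogen on the shared core, and it was large: an at least 12-fold higher number from compound 1 to compound 2 (1.10 log units; beyond the scatter), driving the number to a limit. A step of that kind, toward a higher number, is therefore expected in this assay, quite possibly again ending at a limit rather than a number. Compound 4 is estimated at 4000 nM, with a range from 1000 nM to 20000 nM. The expected step is an 11-fold higher number from compound 3 to compound 4 (1.03 log units; beyond the scatter).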

Compound 4, concentration for half-maximal activity: > 1000 nM
Compound 4: a limit, no number; the forecaster's own chance of this, stated with the estimate: 70%; the middle value does not contradict the limit.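

In this assay the methyl on the aromatic carbon, ortho to a large group, gives an at least 2.7-fold higher number from compound 3 to compound 4 (0.43 log units; beyond the scatter), so the rise seen on the core of compound 1 appears on the core of compound 3 as well. The direction of this change therefore holds on both cores shown, and no pair here goes against it: the same change on two cores in this assay, an at least 12-fold higher number (1.10 log units; beyond the scatter) from compound 1 to compound 2 and an at least 2.7-fold higher number (0.43 log units; beyond the scatter) from compound 3 to compound 4; the limit leaves it open whether they differ Compound 2 and compound 4 both stand at a limit of the assay and not at a number, so neither step has a measured end: the limit of > 1000 nM in this assay, at which 2 of the 4 values shown sit.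

As far as these compounds go, whether the true numbers of compound 2 and compound 4 differ stays open, and with it whether the methyl has the same effect on the two cores. Also open, from the compounds shown here alone, is whether another group at this position, such as a fluorine, a methoxy or a hydroxyl, would leave a number close to that of compound 3 or would end at the same limit as the methyl does.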